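Working notes on the step from compound 1 to compound 4

The source may report more compounds than this note shows. Statements on the series, on what has been measured and on what is new or still open speak of the compounds shown alone.

Measured compounds:
compound 1 `CSCC/C=N/Nc1nc(N)c2ncn([C@@H]3O[C@H](CO)[C@@H](O)[C@H]3O)c2n1`: limit only, > 10000 nM
compound 2 `Nc1nc(N/N=C/c2ccc(OCc3ccccc3)c(OCc3ccccc3)c2)nc2c1ncn2[C@@H]1O[C@H](CO)[C@@H](O)[C@H]1O`: limit only, > 10000 nM
compound 3 `COc1cc(/C=N/Nc2nc(N)c3ncn([C@@H]4O[C@H](CO)[C@@H](O)[C@H]4O)c3n2)ccc1OCc1ccccc1`: 9140 nM

In an assay on CHO-K1 cells for displacement of a labelled ligand from adenosine receptor A1 (Homo sapiens), read by scintillation counting, with a stated time of 60 min (on this read-out lower numbers stand for stronger inhibition and higher numbers for weaker inhibition), compound 1 gives only a limit of the assay, > 10000 nM. Compound 2 also sits at a limit, > 10000 nM. Going by the values given here, compound 3 is the one compound with a number, 9140 nM, and that number lies close to the limit of > 10000 nM in this assay, at which 2 of the 3 values shown sit. So compound 1 stands at the limit, alongside compound 2, with compound 3 the only value just inside it.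

Compound 4 `CCCCc1nc(/C=N/Nc2nc(N)c3ncn([C@@H]4O[C@H](CO)[C@@H](O)[C@H]4O)c3n2)c(Cl)[nH]1` differs from compound 1 by 2-butyl-5-chloro-1H-imidazol-4-yl in place of 2-(methylsulfanyl)ethyl on a carbon with a double bond to nitrogen. Among the compounds with values here, the single measured step, an at least 1.0-fold lower number from compound 2 to compound 3 (0.03 log units; that floor lies within the scatter), concerns another place in the molecule and stays within the scatter, so it offers no guide to the size or direction of the present change. There is thus no measured basis for expecting compound 4 to move beyond the scatter of compound 1.

Compound 4 is therefore expected to give about 9000 nM, within 2500 nM to 30000 nM in this assay, with a real chance that only a limit is reported. The expected step is an at least 1.1-fold lower number from compound 1 to compound 4 (0.04 log units; that floor lies within the scatter).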

Compound 4, inhibition constant: 12 nM
Compound 4: middle estimate off by 750-fold (2.88 log units), on the high side, and the stated range ends above it.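

In this assay, the group on the carbon with a double bond to nitrogen proves able to move the read-out strongly: 2-butyl-5-chloro-1H-imidazol-4-yl in place of 2-(methylsulfanyl)ethyl gives an at least 830-fold lower number from compound 1 to compound 4 (2.92 log units; beyond the scatter). The step is a floor, as compound 1 gives only a limit. Compound 4 is the first compound shown to lie far inside the limit that held the earlier compounds: the limit of > 10000 nM in this assay, at which 2 of the 4 values shown sit.

The butyl chain, the chlorine and the five-membered aromatic ring enter together, so the compounds shown cannot assign the step to any one of them. On these data alone, whether a hydrogen in place of the chlorine, or a propyl chain in place of the butyl chain, would keep the value that compound 4 gives, 12 nM, stays open.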